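Ethoxy for Chloro in a Series at the Assay Ceiling

The compounds below may be only part of what the source reports. "The series", "measured", "known", "first", "only" and "open" are said of these compounds alone.

Compound 1 `FC(F)(F)c1ccc(CSc2nc(N3CCCCC3)c3ccccc3n2)cc1`: in a functional assay on HGC-27 cells (Homo sapiens) for cytotoxicity, read by MTT assay, with a stated time of 72 h (a higher number here means a weaker inhibitor, a lower number a stronger inhibitor), compound 1 gives > 50000 nM, a limit.
Compound 2 `FC(F)(F)c1ccc(CSc2nc(Nc3ccccc3C(F)(F)F)c3ccccc3n2)cc1`: compound 2 gives > 50000 nM, a limit.
Compound 3 `FC(F)(F)c1ccc(CSc2nc(Nc3ccccc3Cl)c3ccccc3n2)cc1`: compound 3 gives > 50000 nM, a limit.

Compound 3 therefore stands at the ceiling of this assay, as the limit of > 50000 nM in this assay, at which 3 of the 3 values shown sit, records for every compound measured. Compound 4 `CCOc1ccccc1Nc1nc(SCc2ccc(C(F)(F)F)cc2)nc2ccccc12` differs from compound 3 by ethoxy in place of chloro on an aromatic carbon. The closest measured step, a step that the two limits leave unreadable from compound 2 to compound 3, also swaps one group for another on an aromatic carbon, but it runs between two limits and its size cannot be read; the same is true of a step that the two limits leave unreadable from compound 1 to compound 3. Within the data shown here, no measured step thus gives a direction. Compound 4 is expected to stay at the ceiling, an estimated a number no higher from compound 3 to compound 4 (the limit leaves the size open), with an expected value of 50000 nM and a range from 15000 nM to 100000 nM.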

Compound 4, half-maximal inhibitory concentration: > 50000 nM
Compound 4: no number, only a limit; the forecaster's own chance of this, stated with the estimate: 75%; the middle value sits exactly at the limit.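

In this assay, among these compounds, compound 4 gives > 50000 nM, a limit, so no step from compound 1, compound 2 or compound 3 to compound 4 can be read. The compounds shown leave open whether any change to the shared core would give a measurable value.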